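Cytotoxicity of Three Measured Analogues and a Fourth

The source may report more compounds than this note shows. Statements on the series, on what has been measured and on what is new or still open speak of the compounds shown alone.

In an ADME assay on Vero cells (Chlorocebus sabaeus) for cytotoxicity, read by MTT assay, with a stated time of 72 h (on this read-out higher numbers stand for lower toxicity in this test and lower numbers for higher toxicity in this test), the measured compounds stand as follows:
Compound 1 `O=C1Oc2ccccc2N/C1=C\C(=O)c1cccs1`: > 1840000 nM, a limit of the assay.
Compound 2 `O=C1Oc2ccccc2N/C1=C\C(=O)c1cccc(Cl)c1`: 1610000 nM.
Compound 3 `Cc1cccc(C(=O)/C=C2\Nc3ccccc3OC2=O)c1`: > 1790000 nM, a limit of the assay.

Compound 3 therefore holds only a limit in this assay, not a number, and compound 1 holds one too, at the limit of > 1840000 nM in this assay, at which 1 of the 3 values shown sits. Among the measured compounds shown here, compound 2 is the single value read as a number. The steps that reach compound 3 are small or unreadable: a step that the two limits leave unreadable from compound 1 to compound 3, and an at least 1.1-fold higher number from compound 2 to compound 3 (0.04 log units; that floor lies within the scatter), while an at least 1.1-fold lower number from compound 1 to compound 2 (0.05 log units; that floor lies within the scatter). Compound 4 `O=C1Oc2ccccc2N/C1=C\C(=O)c1ccccc1Cl` differs from compound 3 by 2-chlorophenyl in place of 3-methylphenyl on a carbonyl carbon. Because the steps among compounds 1 to 3 stay within the scatter (an at least 1.1-fold higher number from compound 2 to compound 3 (0.04 log units; that floor lies within the scatter)), no step beyond the scatter is expected in this assay, so an at least 1.1-fold lower number from compound 3 to compound 4 (0.04 log units; that floor lies within the scatter) is the expected outcome. Compound 4 is accordingly estimated at 1600000 nM, in the range 700000 nM to 3000000 nM.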

Compound 4, half-maximal cytotoxic concentration: 1570000 nM
Compound 4: middle estimate off by 1.0-fold (0.01 log units), on the high side; low and high end bracket the measured number.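

In this assay, among the compounds shown here, the change from 3-chlorophenyl to 2-chlorophenyl on a carbonyl carbon gives the first step here to compound 4 that joins two numbers (a 1.0-fold lower number from compound 2 to compound 4 (0.01 log units; within the scatter)), so moving the chlorine on this phenyl ring leaves no mark beyond the scatter. The steps from thiophen-2-yl and 3-methylphenyl to 2-chlorophenyl are floors only (an at least 1.1-fold lower number from compound 1 to compound 4 (0.06 log units; that floor lies within the scatter) and an at least 1.1-fold lower number from compound 3 to compound 4 (0.05 log units; that floor lies within the scatter)).

The compounds shown leave open whether an amine or a carboxylic acid on the aromatic ring would give any step beyond the scatter in this assay at this position.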